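The compounds below may be only part of what the source reports. "The series", "measured", "known", "first", "only" and "open" are said of these compounds alone.

In a functional assay on K562/A02 cells (Homo sapiens) for antiproliferative activity, read by MTT assay (on this read-out lower numbers stand for stronger inhibition and higher numbers for weaker inhibition), compound 1 `Cc1ccccc1/C(=N/NC(=S)NCCCCCC(=O)NO)c1ccccc1` gives 4220 nM and compound 2 `C/C(=N\NC(=S)NCCCCCC(=O)NO)c1ccc(Br)cc1` gives 440 nM as the lower of the two numbers, a gap beyond the usual scatter. Compound 3 `C/C(=N\NC(=S)NCCCCCC(=O)NO)c1cccc(C)c1` is still unmeasured. It carries 3-methylphenyl in place of 4-bromophenyl on a carbon with a double bond to nitrogen. The two measured compounds differ in more than one place, so the expectation is rough: a moderate move toward weaker inhibition, with a 2.0-fold higher number from compound 2 to compound 3 (0.31 log units; beyond the scatter) estimated for this change. In this assay compound 3 is expected at 900 nM within an estimated range from 300 nM to 3000 nM for now.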

Compound 3, half-maximal inhibitory concentration: 3570 nM
Beside the measured number, compound 3's estimate is 4.0-fold (0.60 log units) below it, outside the stated range (above it).
By their numbers in this assay, from the lowest: compound 2; then compounds 3 and 1 (each within the scatter of the next).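

Within this assay, the change from 4-bromophenyl to 3-methylphenyl on a carbon with a double bond to nitrogen gives an 8.1-fold higher number from compound 2 to compound 3 (0.91 log units; beyond the scatter), the first comparison here that isolates one place, and it shows that the result depends on the group held there. The two groups match in heavy-atom count and hydrogen-bond counts, so those counts do not separate them. Nothing available explains the step.

The swap alters both the substituent and its numbered ring location, and these compounds do not separate the two. Going by these compounds, how an amine or a methoxy group on this phenyl ring would behave also remains open.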